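This account rests on a few compounds, and the source may have more. Where it says the series, first, only, none or still open, it means among the compounds named here.

In a functional assay on MDA-MB-231 cells (Homo sapiens) for cytotoxicity, read by MTT assay, with a stated time of 72 h; on this read-out higher numbers stand for weaker inhibition and lower numbers for stronger inhibition:
Compound 1 `CCN(CC)CCCNc1nc(-c2ccc(NC(=O)Nc3ccccc3)cc2)nc2c(Cl)c(Cl)sc12` gives 1780 nM.
Compound 2 `CCN(CC)CCCNc1nc(-c2ccc(NC(=O)Nc3ccc(Cl)cc3)cc2)nc2c(Cl)c(Cl)sc12` gives 660 nM.

Among the compounds with values here, compound 2 gives the lowest of the two numbers; the only measured step, a 2.7-fold lower number from compound 1 to compound 2 (0.43 log units; beyond the scatter), alters a group on an aromatic ring and leaves the chain untouched. Compound 3 `CCN(CC)CCNc1nc(-c2ccc(NC(=O)Nc3ccc(Cl)cc3)cc2)nc2c(Cl)c(Cl)sc12` differs from compound 2 by diethylamino in place of (diethylamino)methyl on a saturated chain carbon, two bonds along the chain from a nitrogen on an aromatic ring, a shortening of the chain. Within the data shown here, no measured step bears on this chain, so the measured step gives no guide here, and for compound 3 no change beyond the scatter is expected in this assay: a 1.1-fold higher number from compound 2 to compound 3 (0.03 log units; within the scatter). The estimate for compound 3 in this assay is 700 nM, with a range from 250 nM to 2000 nM.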

Compound 3, half-maximal inhibitory concentration: 750 nM
Compound 3: the middle estimate sits 1.1-fold (0.03 log units) below what was measured; low and high end bracket the measured number.
By their numbers in this assay, from the lowest: compounds 2 and 3 (each within the scatter of the next); then compound 1.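

Shortening the side chain from (3-(diethylamino)propyl)amino to (2-(diethylamino)ethyl)amino gives a 1.1-fold higher number from compound 2 to compound 3 (0.06 log units; within the scatter) in this assay, so the two chain lengths cannot be told apart on this read-out. Within the data shown here, this is the first measured step at this chain, since the earlier step changed only a group on an aromatic ring. No outside evidence bears on this result.

The compounds shown leave open whether a longer chain, such as 4-(diethylamino)butyl, would behave the same way. They also leave open what a different amine at the chain end, such as morpholine or dimethylamino, would do.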